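A few compounds are considered here, and "the series" means these few. Any claim that something is new, unique, unknown or untested is made for them only; others in the source may bear on it.

Measured so far:
- compound 1, `N=C(N)c1ccc(-c2ccc(-c3ccc(Cl)cc3)s2)cc1F`: 200 nM
- compound 2, `COc1cc(OC)cc(-c2ccc(-c3ccc(C(=N)N)c(F)c3)s2)c1`: 208 nM

Both compounds were tested in a functional assay on COLO 205 cells (Homo sapiens) for inhibition, read by sulforhodamine B assay, with a stated time of 48 h; a lower number here means a stronger inhibitor of growth, a higher number a weaker inhibitor of growth. Compound 1 gives the lowest of the two numbers, 200 nM, but compound 2, with 208 nM, sits within the scatter of it, so the two cannot be told apart on this assay. The unmeasured compound 3, `COc1ccc(-c2ccc(-c3ccc(C(=N)N)c(F)c3)s2)cc1`, differs from compound 1 in one place: methoxy in place of chloro on an aromatic carbon. Going by the values given here, no step between measured compounds matches this exact exchange, so there is no measured guide for it. Since compound 1 and compound 2, which differ only in what hangs on the outer ring, give numbers within the scatter of each other, a step from compound 1 to compound 3 of no more than the usual scatter, in either direction, is expected. Compound 3 is therefore estimated at 250 nM, within a range of 100 nM to 650 nM, which amounts to an expected step of a 1.3-fold higher number from compound 1 to compound 3 (0.10 log units; within the scatter).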

Compound 3, concentration for 50% growth inhibition: 1780 nM
Estimate against measurement, compound 3: 7.1-fold (0.85 log units) below; measured number outside the range, above it.
By their numbers in this assay, from the lowest: compounds 1 and 2 (each within the scatter of the next); then compound 3.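

Putting methoxy in place of chloro on an aromatic carbon, para to a large group, gives in this assay an 8.9-fold higher number from compound 1 to compound 3 (0.95 log units; beyond the scatter) and so a weaker inhibitor of growth. Going by these compounds alone, this is the first single exchange with a measured result in this set, and it shows that the group at this place on the six-membered aromatic ring can change the number well beyond ordinary repeat variation, with the rest of the molecule held the same.

A single exchange cannot show whether other groups at this place, such as fluoro, methyl, an amine or a carboxylic acid, would give numbers close to compound 1 or to compound 3, or whether any would improve on compound 1. The data shown contain no separate measurement that explains this step.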